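Adding a Third Acetoxy Group to an Inactive Coumarin Diester

The source may report more compounds than this note shows. Statements on the series, on what has been measured and on what is new or still open speak of the compounds shown alone.

Compound 1 `CC(=O)Oc1ccc2cc(-c3ccccc3)c(=O)oc2c1OC(C)=O` carries two acetoxy groups on the shared core and a plain phenyl group. In an assay on CHO cells for displacement of a labelled ligand from adenosine receptor A2b (Homo sapiens), read by radioligand binding (a higher number here means a weaker inhibitor, a lower number a stronger inhibitor), compound 1 gives > 30000 nM, which is a limit of this assay rather than a number. Compound 2 `CC(=O)Oc1ccc(-c2cc3ccc(OC(C)=O)c(OC(C)=O)c3oc2=O)cc1` adds an acetoxy group to the phenyl ring. In this assay compound 2 gives > 30000 nM, again only a limit. The step that the two limits leave unreadable from compound 1 to compound 2 therefore cannot be read in size, since the limit of > 30000 nM in this assay, at which 2 of the 2 values shown sit, marks where both values sit. Compound 3 `CC(=O)Oc1ccc(-c2cc3ccc(OC(C)=O)c(OC(C)=O)c3oc2=O)cc1OC(C)=O` goes one step further: acetoxy in place of hydrogen on an aromatic carbon. The only measured step that bears on this change is the one from compound 1 to compound 2, and it was left unreadable; the two compounds shown both sit at the limit, so no direction of change can be drawn from them. The expected step that the limit leaves unreadable from compound 2 to compound 3 is thus no change beyond the scatter, with compound 3 expected to remain at or beyond the limit. Compound 3 is estimated at 50000 nM, within 15000 nM to 200000 nM.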

Compound 3, inhibition constant: > 30000 nM
Compound 3 gave a limit, no number; the forecaster's own chance of this, stated with the estimate: 85%; the middle value lies beyond the limit too.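

In this assay compound 3 gives > 30000 nM, which is a limit and not a number, so the step from compound 2 to compound 3 cannot be read: the limit of > 30000 nM in this assay, at which 3 of the 3 values shown sit. The compounds shown leave open how strongly any of them binds, and whether adding acetoxy groups changes that at all.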